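Bromo in Place of Fluoro: What the Numbers Suggest

The source may report more compounds than this note shows. Statements on the series, on what has been measured and on what is new or still open speak of the compounds shown alone.

Compound 1, `O=S(=O)(Nc1ccc(-c2nc3cc(NS(=O)(=O)c4cccc5ccccc45)ccc3o2)cc1)c1cccc2ccccc12`, gives 31000 nM in a functional assay on HT-29 cells (Homo sapiens) for cytotoxicity, read by resazurin assay, with a stated time of 48 h; on this read-out lower numbers stand for an effect already at smaller amounts and higher numbers for an effect only at larger amounts of compound.
Compound 2, `COc1ccc(S(=O)(=O)Nc2ccc3oc(-c4ccc(NS(=O)(=O)c5cc(F)ccc5OC)cc4)nc3c2)cc1`, gives 15000 nM in this assay.
Compound 3, `COc1ccccc1S(=O)(=O)Nc1ccc(-c2nc3cc(NS(=O)(=O)c4ccccc4OC)ccc3o2)cc1`, gives 16000 nM in this assay.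

Compound 2 has the lowest of the three numbers. Its nearest neighbour is compound 3, whose number lies within the usual scatter of compound 2, so no order between these two can be claimed. Compound 1 stands furthest away, and its gap to compound 2 is beyond the scatter, so compound 1 needs more of the compound for the same effect than compound 2 does.

Compound 4, `COc1ccc(S(=O)(=O)Nc2ccc3oc(-c4ccc(NS(=O)(=O)c5cc(Br)ccc5OC)cc4)nc3c2)cc1`, has not yet been measured in this assay. It differs from compound 2 in a single place: bromo in place of fluoro on an aromatic carbon. Within the data shown here, nothing among the measured compounds shows a halogen at this position being varied against its neighbour, so the expectation rests on the small size of the change and on the closeness of compound 2 and compound 3. The step from compound 2 to compound 4 is expected to stay within the scatter, in neither direction. Compound 4 is therefore estimated at 14000 nM, with a range from 6000 nM to 35000 nM, which means an expected step of a 1.1-fold lower number from compound 2 to compound 4 (0.03 log units; within the scatter).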

Compound 4, half-maximal effective concentration: 14000 nM
The estimate for compound 4 equals the measured number at the digits printed, and the stated range covers the measured number.
By their numbers in this assay, from the lowest: compounds 4, 2, 3 and 1 (each within the scatter of the next, the first and the last beyond it).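

In this assay, bromo in place of fluoro on the 5-fluoro-2-methoxyphenyl group, para to a methoxy group and meta to a large group, gives a 1.1-fold lower number from compound 2 to compound 4 (0.03 log units; within the scatter). This is the first pair among the compounds shown that differs at this position alone, and it shows that the two halogens cannot be told apart here on this read-out. No order between compound 2 and compound 4 can be claimed, so this one exchange leaves the number where it was, and no measurement at hand speaks to why that is so.

From the compounds shown here alone, whether this position stays as undemanding for groups other than a halogen remains open, since an amine, a carboxylic acid or a longer chain such as an ethoxy group in place of the bromo might or might not keep the number within the scatter of compound 2. Going by these compounds, it is also open whether bromo in place of fluoro would read the same way if the rest of the molecule carried different groups, as one pair at one position cannot settle that.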